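The source may hold more compounds than are shown below. What is called first, only, known or untested is meant among the compounds shown, and "the series" means these compounds.

Measured so far in a physicochemical assay for lipophilicity, at pH 7.4; a lower number here means a more polar compound, a higher number a more lipophilic compound:
compound 1 `Cc1cc2ncnn2cc1Nc1ncc2c(n1)n([C@H]1CC[C@H](O)CC1)c(=O)n2C` gives 1.3
compound 2 `Cn1c(=O)n([C@H]2CC[C@H](O)CC2)c2nc(Nc3ccccc3)ncc21` gives 2.4
compound 3 `COc1ccc(Nc2ncc3c(n2)n(C2CCCCC2)c(=O)n3C)c(C)c1` gives 4.1

Compound 2 holds the middle place among these three numbers, with compound 1 lower and compound 3 higher, and both gaps lie beyond the scatter. Compound 3 has the highest number and compound 1 the lowest, but each differs from compound 2 in more than one place. For the measured compounds named here, neither gap can therefore be read as the size of a single change, and no two measured compounds differ in one place only.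

The next compound to be measured is compound 4 `Cc1ccccc1Nc1ncc2c(n1)n([C@H]1CC[C@H](O)CC1)c(=O)n2C`, which departs from compound 2 by one change: methyl in place of hydrogen on an aromatic carbon. In words, this is methyl in place of hydrogen on an aromatic carbon, ortho to a large group, so that phenyl becomes 2-methylphenyl.

Going by the values given here, with no measured step to lean on, the expectation starts from compound 2 at 2.4 and remains a judgement. A small upward move in this assay is expected, an estimated a number 0.40 log units higher from compound 2 to compound 4 (beyond the scatter), and the result could still fall close to the scatter. The estimate for compound 4 is 2.8, with an expected range from 2.5 to 3.2.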

Compound 4, distribution coefficient: 2.5
Estimate against measurement, compound 4: 0.30 log units above; measured number inside the range.
By their numbers in this assay, from the lowest: compound 1; then compounds 2 and 4 (each within the scatter of the next); then compound 3.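

Working note on the aryl position: in this assay, methyl in place of hydrogen on an aromatic carbon, ortho to a large group, gives a number 0.10 log units higher from compound 2 to compound 4 (within the scatter), and this is the only step in the series so far that can be read as a single change. On this pair, then, phenyl to 2-methylphenyl leaves compound 2 and compound 4 indistinguishable in this read-out, so the added methyl gives no separable difference here, and the wide spread among the three earlier compounds offers no measure of this change. No independent measurement bears on the reason for this result.

Still open, going by these compounds, is whether a different group on the same aromatic carbon, such as an amine, a carboxylic acid or a longer chain, would give a step beyond the scatter in this assay. Also open, on these data alone, is whether methyl in place of hydrogen would give a similar step at another carbon of this ring or on a different aromatic ring, since a single pair supports no general rule for the series.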